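The source may report more compounds than this note shows. Statements on the series, on what has been measured and on what is new or still open speak of the compounds shown alone.

Measured in a functional assay on MCF7 cells (Homo sapiens) for cytotoxicity, read by MTT assay, with a stated time of 96 h; a lower number here means a stronger inhibitor, a higher number a weaker inhibitor:
- compound 1 `COc1cc(C(=O)c2cn(-c3ccccc3)cc2-c2ccc(N)cc2)cc(OC)c1OC`: 9 nM
- compound 2 `COc1cc(C(=O)c2cn(-c3ccccc3)cc2-c2ccccc2Br)cc(OC)c1OC`: 190 nM
- compound 3 `COc1cc(C(=O)c2cn(-c3ccccc3)cc2-c2ccccc2[N+](=O)[O-])cc(OC)c1OC`: 49 nM

Compound 3 holds the middle of these three numbers, with a 5.4-fold higher number from compound 1 to compound 3 (0.74 log units; beyond the scatter) and a 3.9-fold lower number from compound 2 to compound 3 (0.59 log units; beyond the scatter).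

Next is compound 4 `COc1cc(C(=O)c2cn(-c3ccccc3)cc2-c2cccc([N+](=O)[O-])c2)cc(OC)c1OC`, with 3-nitrophenyl in place of 2-nitrophenyl on an aromatic carbon.

Going by the values given here, no measured step moves the nitro group alone, so the evidence is indirect. The step of a 3.9-fold lower number from compound 2 to compound 3 (0.59 log units; beyond the scatter) exchanges the group but keeps its place. The steps of a 5.4-fold higher number from compound 1 to compound 3 (0.74 log units; beyond the scatter) and a 21-fold higher number from compound 1 to compound 2 (1.32 log units; beyond the scatter) change group and place together, so they show how far this aryl position can move this assay but give no direction for the nitro move. A step beyond the scatter is therefore not expected, though a modest one either way remains possible. The expected change is a 1.2-fold lower number from compound 3 to compound 4 (0.09 log units; within the scatter). For compound 4 the estimated value is 40 nM, with an expected range of 12 nM to 130 nM.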

Compound 4, half-maximal inhibitory concentration: 50 nM
Compound 4: middle estimate off by 1.3-fold (0.10 log units), on the low side; low and high end bracket the measured number.
By their numbers in this assay, from the lowest: compound 1; then compounds 3 and 4 (each within the scatter of the next); then compound 2.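

In this assay, the 2-nitrophenyl and 3-nitrophenyl groups at this position on the shared core read alike, with a 1.0-fold higher number from compound 3 to compound 4 (0.01 log units; within the scatter), so these two nitro placements are not told apart here. The gaps to the other two compounds are both beyond the scatter, with a 3.8-fold lower number from compound 2 to compound 4 (0.58 log units; beyond the scatter) and a 5.6-fold higher number from compound 1 to compound 4 (0.74 log units; beyond the scatter), so the 3-nitrophenyl group, like the 2-nitrophenyl group, stands between the 4-aminophenyl and 2-bromophenyl groups. No available evidence bears on why the two nitrophenyl groups read alike.

Still open, going by these compounds, is whether the lower number of compound 1 belongs to the amine or to its place on the phenyl ring, which a nitro group in that same place would help to separate. Also open, on these data alone, is how a carboxylic acid or a nitrile on this phenyl ring would read.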